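Cyclobutylcarbonyl in place of isobutylcarbonyl on a shared core

The source may report more compounds than this note shows. Statements on the series, on what has been measured and on what is new or still open speak of the compounds shown alone.

The series starts from compound 1 `Nc1ncc(-c2cccc(Cl)c2)c(-c2ccccc2)n1`, which carries a hydrogen on a nitrogen on an aromatic ring. In an assay on CHO cells for displacement of a labelled ligand from adenosine receptor A1 (Homo sapiens), read by scintillation counting, with a stated time of 1 h, tested at 1 uM (a lower number here means less inhibition, a higher number more inhibition at the concentration tested (going by the name of the read-out)), compound 1 gives > 80%, a limit of the assay rather than a number (the limit of > 80% in this assay, at which 1 of the 3 values shown sits). Compound 2 `CCCCC(=O)Nc1ncc(-c2cccc(Cl)c2)c(-c2ccccc2)n1` bears butylcarbonyl in place of that hydrogen and gives 52% in this assay. The step is a number at least 28 percentage points lower from compound 1 to compound 2 (beyond the scatter). Compound 3 `CC(C)CC(=O)Nc1ncc(-c2cccc(Cl)c2)c(-c2ccccc2)n1` bears isobutylcarbonyl and gives 56% in this assay. That step is a number at least 24 percentage points lower from compound 1 to compound 3 (beyond the scatter). Compound 3 stands level with compound 2: the step between them, a number 4 percentage points higher from compound 2 to compound 3 (within the scatter), lies within the scatter, so neither can be placed above the other.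

Compound 4 `O=C(Nc1ncc(-c2cccc(Cl)c2)c(-c2ccccc2)n1)C1CCC1` is the next step from compound 3: cyclobutyl in place of isobutyl on a carbonyl carbon. For the measured compounds named here, both acyl groups seen so far, butylcarbonyl and isobutylcarbonyl, have given much the same inhibition, and the only step between two acylated compounds, a number 4 percentage points higher from compound 2 to compound 3 (within the scatter), is within the scatter. The change to cyclobutyl keeps an acyl group of the same size on the nitrogen, so compound 4 is expected to sit with compound 2 and compound 3 rather than with compound 1. Compound 4 is therefore expected to show a number 1 percentage points lower from compound 3 to compound 4 (within the scatter), nothing beyond the scatter. For compound 4 the estimated value is 55%, within a range from 40% to 70%.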

Compound 4, a percentage reported as inhibition, at one concentration (the size of the read-out at that concentration, not a potency): 52%
Estimate against measurement, compound 4: 3 percentage points above, within the range that was stated.
By their numbers in this assay, from the lowest: compounds 2, 4 and 3 (each within the scatter of the next). At a limit, above all of these: compound 1.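

Cyclobutyl brings a ring onto the carbonyl carbon for the first time, and in this assay this does not separate it from the open chains, with a number 4 percentage points lower from compound 3 to compound 4 (within the scatter) and no change at the digits printed from compound 2 to compound 4 (within the scatter). At this place, then, butyl, isobutyl and cyclobutyl cannot be told apart by these numbers, so a ring of carbon does no more here than either open chain of the compounds shown. The step from the unacylated compound also holds with the ring in place, at a number at least 28 percentage points lower from compound 1 to compound 4 (beyond the scatter), although its true size stays unknown, for compound 1 is held at a limit of the assay, not a number: the limit of > 80% in this assay, at which 1 of the 4 values shown sits.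

On these data alone, whether a smaller ring such as cyclopropyl, a larger one such as cyclohexyl, or an aromatic group such as phenyl on the same carbonyl carbon would stay at this level remains open, as does the effect of a chain ending in an amine or a carboxylic acid. As far as these compounds go, it is also open whether a short acyl group such as acetyl would lie with compounds 2, 3 and 4 or nearer to compound 1.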